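From cyclobutyl to cyclopentyl on the free-fraction scale

The source may report more compounds than this note shows. Statements on the series, on what has been measured and on what is new or still open speak of the compounds shown alone.

In an ADME assay on the whole organism (plasma, Mus musculus, strain CD-1) for protein binding, read by LC-MS, with a stated time of 24 h (on this read-out higher numbers stand for a larger free fraction and lower numbers for a smaller free fraction), compound 1 `CN(C(=O)OCc1c(-c2ccc(O[C@H]3CCC[C@H](C(=O)O)C3)cc2)cnn1C)C1CCCC1` gives 0.013 and compound 2 `CN(CC1CCC1)C(=O)OCc1c(-c2ccc(O[C@H]3CCC[C@H](C(=O)O)C3)c(C(F)F)n2)nnn1C` gives 0.035 while compound 3 `Cc1nc(-c2nnn(C)c2COC(=O)N(C)CC2CCC2)ccc1O[C@H]1CCC[C@H](C(=O)O)C1` stands highest of the three at 0.1 on this scale. The difference cyclopentyl in place of cyclobutyl on a saturated chain carbon bound to an amide-type nitrogen separates compound 4 `Cc1nc(-c2nnn(C)c2COC(=O)N(C)CC2CCCC2)ccc1O[C@H]1CCC[C@H](C(=O)O)C1` from compound 3: cyclopentyl in place of cyclobutyl on a saturated chain carbon bound to an amide-type nitrogen. For the measured compounds named here, no measured step covers this change. Going by the values given here, the only measured step of a 2.9-fold higher number from compound 2 to compound 3 (0.46 log units; beyond the scatter) lies at another place and bears on it only loosely. Compound 1 also carries cyclopentyl, with 0.013 as its number, but it differs from compound 3 elsewhere too. A small move toward a lower number is therefore expected, with a 1.7-fold lower number from compound 3 to compound 4 (0.22 log units; within the scatter) as the estimated step. In this assay compound 4 is estimated at 0.06 with a range from 0.03 to 0.11 around it.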

Compound 4, unbound fraction: 0.065
Estimate against measurement, compound 4: 1.1-fold (0.03 log units) below; the range from low to high includes it.
By their numbers in this assay, from the lowest: compound 1; then compounds 2, 4 and 3 (each within the scatter of the next, the first and the last beyond it).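

In this assay, cyclopentyl in place of cyclobutyl on a saturated chain carbon bound to an amide-type nitrogen gives a 1.5-fold lower number from compound 3 to compound 4 (0.19 log units; within the scatter). For the compounds shown here, this is the first reading of this change with the rest of the structure held constant, and it shows that the free fraction at this position tolerates the five-membered ring in place of the four-membered one. Nothing available explains this result.

Going by these compounds, it remains open how a cyclohexyl ring, an open butyl chain or a ring carrying an ether oxygen would read at this position. On these data alone, it also remains open whether the step would hold in compound 2, which carries difluoromethyl.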